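Swapping an Aminomethoxyphenyl for a tert-Butylphenyl

This account rests on a few compounds, and the source may have more. Where it says the series, first, only, none or still open, it means among the compounds named here.

Compound 1 `COc1ccc(-c2cc3nccc(-c4cc(OC)c(OC)c(OC)c4)n3n2)cc1N` was tested in a functional assay on HeLa cells (Homo sapiens) for inhibition, read by CCK-8 assay, with a stated time of 48 h (a higher number here means a weaker inhibitor, a lower number a stronger inhibitor), where compound 1 gives 283 nM. Among the compounds that returned a number, compound 1 has the lower one. Compound 2 `Cn1ccc2cc(-c3cc4nccc(-c5ccc(F)cc5)n4n3)ccc21` gives 5210 nM in this assay, a higher number that lies beyond the scatter of the measurement. Compound 3 `COc1cc(-c2ccnc3c(-c4ccc(C)cc4)cnn23)cc(OC)c1OC` returns no number in this assay but only a limit of the assay, > 10000 nM. Thus one of the three results stands at the limit of > 10000 nM in this assay, at which 1 of the 3 values shown sits.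

Compound 4 `COc1cc(-c2ccnc3cc(-c4ccc(C(C)(C)C)cc4)nn23)cc(OC)c1OC` has not yet been measured. It keeps the shared core of compound 1 and differs in one place: 4-(tert-butyl)phenyl in place of 3-amino-4-methoxyphenyl on an aromatic carbon. No measured pair here isolates such a swap, so the expectation rests on the numbers shown. Compound 4 is expected to give 3000 nM in this assay, with a plausible range from 700 nM to 15000 nM. The expected step of an 11-fold higher number from compound 1 to compound 4 (1.03 log units; beyond the scatter) points toward a weaker inhibitor and is estimated to exceed the scatter, though a limit rather than a number cannot be ruled out.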

Compound 4, half-maximal inhibitory concentration: > 10000 nM
Compound 4 gave a limit, no number; the forecaster's own chance of this, stated with the estimate: 25%; middle value at least 3.3-fold (0.52 log units) from the limit.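

For the compounds shown here, the pair of compound 1 and compound 4 is the first here to differ in one place only, and it shows that the group on this aromatic carbon of the five-membered ring matters greatly in this assay: the swap gives an at least 35-fold higher number from compound 1 to compound 4 (1.54 log units; beyond the scatter). Compound 4 stands at > 10000 nM, which is a limit of the assay and not a number. With this result, a second compound now sits at that limit: the limit of > 10000 nM in this assay, at which 2 of the 4 values shown sit.

The swap removes the amine and the methoxy together and brings in the tert-butyl, so the data cannot tell which of these changes accounts for the step. A plain 3-aminophenyl or 4-methoxyphenyl group on this same carbon would separate the amine from the methoxy, and neither group is among the compounds shown.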